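Efficacy at the prostaglandin D2 receptor 2: pyridyl variation

The source may hold more compounds than are shown below. What is called first, only, known or untested is meant among the compounds shown, and "the series" means these compounds.

Measured compounds:
compound 1 `Nc1cc(-c2nc(C(c3ccc(F)cc3)c3ccc(F)cc3)sc2CC(=O)O)cc(F)n1`, 30%
compound 2 `O=C(O)Cc1sc(C(c2ccccc2)c2ccccc2)nc1-c1ccc(F)c(F)c1`, 80%
compound 3 `O=C(O)Cc1sc(C(c2ccccc2)c2ccccc2)nc1-c1ccccc1`, 80%

In an in vitro functional assay on HEK285-7 cells for antagonist activity at prostaglandin D2 receptor 2 (Homo sapiens), read by BRET and beta-arrestin recruitment (a lower number here means a smaller maximal response, a higher number a larger maximal response), compound 1 gives 30%, the lowest of the three numbers; compound 2 and compound 3 each lie higher, beyond the scatter. Going by the values given here, compound 1 differs from both in two places at once (the aryl on the shared core and the fluorines on the diphenylmethyl group), so no single step connects it to them.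

Compound 4 `O=C(O)Cc1sc(C(c2ccc(F)cc2)c2ccc(F)cc2)nc1-c1ccncc1` has not yet been measured. Its difference from compound 1 is pyridin-4-yl in place of 2-amino-6-fluoropyridin-4-yl on an aromatic carbon. Among the compounds with values here, the one measured step that touches this position is no change at the digits printed from compound 2 to compound 3 (within the scatter), showing that an aryl swap there can leave the maximal response unchanged. Within the data shown here, that step, however, removes ring fluorines only; the amino group lost here has no counterpart in the measured pairs.

Compound 4 removes the amino and the ring fluorine and thus approaches the unsubstituted aryl pattern of compound 2 and compound 3; compound 2 gives 80% and compound 3 gives 80%, both well above compound 1. An upward step is therefore expected, its size uncertain. Compound 4 is estimated at 60%, within 35% to 85%, corresponding to an expected step of a number 30 percentage points higher from compound 1 to compound 4 (beyond the scatter).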

Compound 4, largest response reached (reported as efficacy), in percent of the reference or control that the assay uses: 80%
The estimate for compound 4 lay 20 percentage points below the measured number; low and high end bracket the measured number.
By their numbers in this assay, from the lowest: compound 1; then compounds 2, 3 and 4 (each within the scatter of the next).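

In this assay, going by these compounds alone, the change to pyridin-4-yl in place of 2-amino-6-fluoropyridin-4-yl, on the aromatic carbon next to the ring nitrogen, gives a number 50 percentage points higher from compound 1 to compound 4 (beyond the scatter) and is the first single change at this position to move the maximal response beyond the scatter. The earlier step at this position gave no change at the digits printed from compound 2 to compound 3 (within the scatter), so the position does not tolerate every aryl change equally: removing ring fluorines from a phenyl left this assay unmoved, whereas removing the amino group and the fluorine from the pyridine-based substituent did not. Compound 4 keeps the pyridin-4-yl ring and the fluorines on the diphenylmethyl group and gives 80%, so neither of these features by itself goes with the low number of compound 1.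

The amino group and the ring fluorine leave together in this step, so the compounds shown leave open whether one of them or the pair goes with the lower response. Also open, on these data alone, is how a pyridin-4-yl carrying a methoxy or dimethylamino group in place of the amino group would read out here.

Nothing available explains the size of this step.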